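Trimming the side chain of compound 2

This account rests on a few compounds, and the source may have more. Where it says the series, first, only, none or still open, it means among the compounds named here.

Compound 1 `COc1cc(OC)c(Cl)c(-c2ccc3c(NC(=O)c4ccc(N5CCCCC5)cc4)n[nH]c3n2)c1Cl`: 558 nM
Compound 2 `COc1cc(OC)c(Cl)c(-c2ccc3c(NC(=O)c4ccc(N(C)CCN(C)C)cc4)n[nH]c3n2)c1Cl`: 11 nM
Compound 3 `COc1cc(OC)c(Cl)c(-c2ccc3c(NC(=O)c4ccc(N)cc4)n[nH]c3n2)c1Cl`: not yet measured

Among the compounds with values here, in a functional assay on NCI-H1581 cells (Homo sapiens) for antiproliferative activity, read by CCK-8 assay, with a stated time of 72 h (a lower number here means a stronger inhibitor, a higher number a weaker inhibitor), compound 2 gives 11 nM, the lowest of the two numbers so far. The change to compound 3 is amino in place of (2-(dimethylamino)ethyl)(methyl)amino on an aromatic carbon. Within the data shown here, one measured step bears on it, a 51-fold lower number from compound 1 to compound 2 (1.71 log units; beyond the scatter), which is large and beyond the scatter and brought in the group that now leaves. Losing that group is therefore expected to raise the number considerably, though no measured compound carries amino. The expected change is a 23-fold higher number from compound 2 to compound 3 (1.36 log units; beyond the scatter). The estimate for compound 3 is 250 nM, with an expected range of 60 nM to 900 nM.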

Compound 3, half-maximal inhibitory concentration: 218 nM
Estimate against measurement, compound 3: 1.1-fold (0.06 log units) above; measured number inside the range.
By their numbers in this assay, from the lowest: compound 2; then compound 3; then compound 1.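

In this assay, the step of a 20-fold higher number from compound 2 to compound 3 (1.30 log units; beyond the scatter) shows that the low number of compound 2 depends on the (2-(dimethylamino)ethyl)(methyl)amino group and is not reached with amino at this place. Amino still improves modestly on piperidin-1-yl, with a 2.6-fold lower number from compound 1 to compound 3 (0.41 log units; beyond the scatter) as the step, so piperidin-1-yl gives the highest number of the three compounds. No available evidence explains either step.

The compounds shown leave open which part of the chain matters. A shorter chain ending in a dimethylamine, or a methylpiperazine ring, might or might not retain the low number of compound 2.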